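Fluorine on the aryl ring: carbocycle versus pyridine core

A few compounds are considered here, and "the series" means these few. Any claim that something is new, unique, unknown or untested is made for them only; others in the source may bear on it.

Measured compounds:
compound 1 `C=CC[C@H]1C[C@]2([C@@H](C)Cc3ccc(OC)cc3)OCOC2=CC1=O` 90 nM
compound 2 `C=CC[C@H]1C[C@]2([C@@H](C)Cc3ccc(OC)c(F)c3)OCOC2=CC1=O` 90 nM
compound 3 `C=CC[C@H]1C[C@]2([C@@H](C)Cc3ccc(OC)nc3)OCOC2=CC1=O` 330 nM

In a functional assay on NCI-H460 cells (Homo sapiens) for antiproliferative activity, with a stated time of 72 h (on this read-out higher numbers stand for weaker inhibition and lower numbers for stronger inhibition), compound 1 gives 90 nM and compound 2 gives 90 nM. The change fluoro in place of hydrogen on an aromatic carbon gives no change at the digits printed from compound 1 to compound 2 (within the scatter). The two cores differ as described by 6-methoxypyridin-3-yl in place of 4-methoxyphenyl on a saturated chain carbon, two bonds along the chain from a saturated ring carbon, and this step gives a 3.7-fold higher number from compound 1 to compound 3 (0.56 log units; beyond the scatter), compound 3 giving 330 nM.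

Compound 4 `C=CC[C@H]1C[C@]2([C@@H](C)Cc3cnc(OC)cc3F)OCOC2=CC1=O` is not yet measured. The change from compound 3 to compound 4 is fluoro in place of hydrogen on an aromatic carbon. Among the compounds with values here, it is the same kind of change as the one from compound 1 to compound 2, but the place differs: here the fluoro is ortho to a large group, meta to a methoxy group and opposite the ring nitrogen, whereas before it was ortho to a methoxy group and meta to a large group on a ring of carbon only.

Resting on the step of no change at the digits printed from compound 1 to compound 2 (within the scatter), a step of about no change at the digits printed from compound 3 to compound 4 (within the scatter) is expected here, with wider uncertainty for the shifted place. Compound 4 is estimated at 330 nM, between 150 nM and 750 nM.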

Compound 4, half-maximal inhibitory concentration: > 20000 nM
Compound 4 gave a limit, no number (the forecaster's own chance of this, stated with the estimate: 2%); at least 60-fold (1.78 log units) between middle value and limit.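

In this assay, fluoro in place of hydrogen on an aromatic carbon gives an at least 60-fold higher number from compound 3 to compound 4 (1.78 log units; beyond the scatter), so this change does not carry over unaltered from one core to the other: the same change on two cores in this assay, no change at the digits printed (within the scatter) from compound 1 to compound 2 and an at least 60-fold higher number (1.78 log units; beyond the scatter) from compound 3 to compound 4, at least 60-fold (1.78 log units) apart, beyond the scatter of two such steps. Compound 4 gives > 20000 nM, which is a limit of the assay and not a number. From the compounds shown here alone, the two steps differ in both the ring and the place of the fluoro, the data do not separate these two differences, and the full size of the step stays unknown.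

The compounds shown leave open what fluoro gives at the place it holds in compound 2 on the core of compound 3, or at the place it holds in compound 4 on the core of compound 1. Going by these compounds, whether chloro or methyl at the place of the fluoro in compound 4 gives a similar result also stays open.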